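The source may report more compounds than this note shows. Statements on the series, on what has been measured and on what is new or still open speak of the compounds shown alone.

Compound 1 `CC(C)[C@H](C(=O)Nc1cnns1)c1ccc(Cl)cc1` gives 57000 nM in a functional assay on CHO cells for agonist activity at Free fatty acid receptor 2 (Homo sapiens), read by cAMP accumulation; on this read-out lower numbers stand for stronger inhibition and higher numbers for weaker inhibition.
Compound 2 `CC(C)[C@H](C(=O)Nc1ncc(C(F)(F)F)s1)c1ccc(Cl)cc1` gives 1500 nM in this assay.
Compound 3 `CC(C)[C@H](C(=O)Nc1ncc(C#N)s1)c1ccc(Cl)cc1` gives 2000 nM in this assay.

Compound 3 stands second highest of the three numbers: compound 2 lies within the scatter of it, while compound 1 lies far above it. Compound 4 `COC(=O)c1cnc(NC(=O)[C@H](c2ccc(Cl)cc2)C(C)C)s1` differs from compound 3 by methoxycarbonyl in place of cyano on an aromatic carbon. Among the measured compounds shown here, two measured steps bear on this. a 29-fold lower number from compound 1 to compound 3 (1.45 log units; beyond the scatter) shows that exchanging the whole ring on the amide nitrogen moved the number a great deal. a 1.3-fold higher number from compound 2 to compound 3 (0.12 log units; within the scatter) shows that swapping the group on the ring carbon left the number within the scatter. For the measured compounds named here, the new change again touches only that ring carbon, so for compound 4 a step no larger than no change at the digits printed from compound 3 to compound 4 (within the scatter) is expected. Compound 4 is therefore estimated at 2000 nM, with a range from 600 nM to 7000 nM.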

Compound 4, half-maximal inhibitory concentration: 2000 nM
Compound 4: the middle estimate sits on the measured number at the digits printed; the measured number falls inside the stated range.
By their numbers in this assay, from the lowest: compounds 2, 3 and 4 (each within the scatter of the next); then compound 1.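

In this assay, methoxycarbonyl brings 4 heavy atoms against the 2 of cyano, and 2 hydrogen-bond acceptors against 1, yet the result is no change at the digits printed from compound 3 to compound 4 (within the scatter). Set against trifluoromethyl, it gives a 1.3-fold higher number from compound 2 to compound 4 (0.12 log units; within the scatter), so all three groups on this aromatic carbon, next to the ring sulfur, read alike within the scatter. Nothing measured here explains why these groups read alike. From the compounds shown here alone, whether an amine, a carboxylic acid or a longer chain on this ring carbon would also stay within the scatter of these values remains open.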